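Formyl addition in a series resting at the assay limit

A few compounds are considered here, and "the series" means these few. Any claim that something is new, unique, unknown or untested is made for them only; others in the source may bear on it.

Compound 2 `Cc1ccc(-c2cn3nc(Cc4ccc(Cl)cc4)sc3n2)cc1` is the reference for the next change. In an ADME assay on CCRF-CEM cells (Homo sapiens) for cytotoxicity, with a stated time of 72 h (a lower number here means a stronger inhibitor, a higher number a weaker inhibitor), compound 2 gives > 250000 nM, which is a limit of the assay and not a number. Compound 1 `Fc1ccc(-c2cn3nc(Cc4ccc(Cl)cc4)sc3n2)cc1` gives > 250000 nM in this assay, again a limit. Compound 3 `O=[N+]([O-])c1ccc(-c2cn3nc(Cc4ccc(Cl)cc4)sc3n2)cc1` gives > 250000 nM in this assay, also a limit. All three rest at the limit of > 250000 nM in this assay, at which 3 of the 3 values shown sit, so a step that the two limits leave unreadable from compound 1 to compound 2, a step that the two limits leave unreadable from compound 1 to compound 3 and a step that the two limits leave unreadable from compound 2 to compound 3 cannot be sized. Compound 4 `Cc1ccc(-c2nc3sc(Cc4ccc(Cl)cc4)nn3c2C=O)cc1` differs from compound 2 by formyl in place of hydrogen on an aromatic carbon. Among the measured compounds shown here, no measured step bears on this change, so its direction and size are open; the shared core has not yet left the limit. Compound 4 is expected to remain near that limit, estimated at 250000 nM, spanning 60000 nM to 1000000 nM. The expected step is a number no higher from compound 2 to compound 4 (the limit leaves the size open).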

Compound 4, half-maximal inhibitory concentration: 17000 nM
Estimate against measurement, compound 4: 15-fold (1.17 log units) above; measured number below the stated range.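

Formyl in place of hydrogen on this aromatic carbon gives an at least 14-fold lower number from compound 2 to compound 4 (1.16 log units; beyond the scatter) in this assay, so a change at this position can bring the series to a readable number. The steps among compounds 1, 2 and 3 cannot be read, and compound 4 alone has left the shared limit: the limit of > 250000 nM in this assay, at which 3 of the 4 values shown sit.

A single change at this carbon cannot show whether the step belongs to the formyl group specifically. A hydroxymethyl group, an aminomethyl group or a carboxylic acid here would test that, and the reason for the step remains open.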